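From cyano to (hydroxymethyl)carbonyl in a toxicity test

The source may report more compounds than this note shows. Statements on the series, on what has been measured and on what is new or still open speak of the compounds shown alone.

Compound 1 `COc1cccc2[nH]c(C(=O)N[C@@H](CC(C)C)C(=O)N[C@H](C#N)C[C@@H]3CCCNC3=O)cc12`: > 200000 nM
Compound 2 `COc1cccc2[nH]c(C(=O)N[C@@H](CC(C)C)C(=O)N[C@H](C#N)C[C@@H]3CCNC3=O)cc12`: > 200000 nM

In a toxicity assay on A549 cells (Homo sapiens) for cytotoxicity, read by CCK-8 assay (on this read-out lower numbers stand for higher toxicity in this test and higher numbers for lower toxicity in this test), compound 1 gives > 200000 nM, which is a limit and not a number. Compound 2 gives > 200000 nM, which is also a limit. Both results sit at one end of the test: the limit of > 200000 nM in this assay, at which 2 of the 2 values shown sit. Compound 1 therefore has no exact place on the scale.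

Among the measured compounds shown here, the only measured step is a step that the two limits leave unreadable from compound 1 to compound 2. It swaps 2-oxopiperidin-3-yl for 2-oxopyrrolidin-3-yl, and it gives no size that could be carried over to another change.

Compound 3 `COc1cccc2[nH]c(C(=O)N[C@@H](CC(C)C)C(=O)N[C@@H](C[C@@H]3CCCNC3=O)C(=O)CO)cc12` keeps the shared core of compound 1 but carries (hydroxymethyl)carbonyl in place of cyano on a saturated chain carbon bound to an amide-type nitrogen and a saturated chain carbon. For the measured compounds named here, no measured step touches this place.

The expected change is a number no higher from compound 1 to compound 3 (the limit leaves the size open), estimated with no firm direction. This expectation rests only on compound 1, whose > 200000 nM is a limit. In this assay the estimated value for compound 3 is 200000 nM, with an expected range from 60000 nM to 400000 nM.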

Compound 3, half-maximal cytotoxic concentration: > 200000 nM
Compound 3: only a limit was reported (the forecaster's own chance of this, stated with the estimate: 75%); the middle value sits exactly at the limit.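

Compound 3 also gives only a limit, so neither the step from compound 1 to compound 3 nor the step from compound 1 to compound 2 can be read, because every result stands at the same end of the test: the limit of > 200000 nM in this assay, at which 3 of the 3 values shown sit.

Going by these compounds, whether (hydroxymethyl)carbonyl in place of cyano changes toxicity at all, and by how much, stays open.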